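The compounds below may be only part of what the source reports. "The series", "measured", "known", "first", "only" and "open" are said of these compounds alone.

Measured in a functional assay on HeLa cells (Homo sapiens) for inhibition, read by MTT assay, with a stated time of 72 h; a higher number here means a weaker inhibitor, a lower number a stronger inhibitor:
Compound 1 `O=[N+]([O-])c1ccc(-c2nnc(SCCCN3CCN(c4nc5ccccc5o4)CC3)o2)cc1`: 114000 nM
Compound 2 `COc1ccc(-c2nnc(SCCCN3CCN(c4nc5ccccc5s4)CC3)o2)cc1`: 165000 nM

Compound 2 lies within the usual scatter of compound 1, so these two numbers cannot be told apart. Compound 3 `O=[N+]([O-])c1ccc(-c2nnc(SCCCN3CCN(c4nc5ccccc5s4)CC3)o2)cc1` keeps the structure of compound 2 but has nitro in place of methoxy on an aromatic carbon, para to a large group: nitro in place of methoxy on an aromatic carbon. Among the measured compounds shown here, no measured pair shows this change alone. Compound 1 already carries 4-nitrophenyl and gives 114000 nM, so no shift beyond the scatter is expected. The expected result is a small step, a 1.3-fold lower number from compound 2 to compound 3 (0.10 log units; within the scatter). The estimated value for compound 3 is 130000 nM, with an expected range of 55000 nM to 300000 nM.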

Compound 3, half-maximal inhibitory concentration: 97800 nM
For compound 3 the middle estimate is 1.3-fold (0.12 log units) above the measured one; measured number inside the range.
By their numbers in this assay, from the lowest: compounds 3, 1 and 2 (each within the scatter of the next).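

In this assay, among the compounds shown here, nitro in place of methoxy on the aromatic carbon, para to a large group, gives a first direct reading of this change (a 1.7-fold lower number from compound 2 to compound 3 (0.23 log units; within the scatter)), and that step lies within the scatter. The swap of 1,3-benzoxazol-2-yl for 1,3-benzothiazol-2-yl on the ring amine nitrogen (a 1.2-fold lower number from compound 1 to compound 3 (0.07 log units; within the scatter)) also lies within the scatter, so neither change separates these compounds. Nothing measured here speaks to the reason. On these data alone, whether an amine or a carboxylic acid at this aromatic carbon would shift the number beyond the scatter stays open. So does the effect of a longer chain.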